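Swapping the amine side chain on a shared core

A few compounds are considered here, and "the series" means these few. Any claim that something is new, unique, unknown or untested is made for them only; others in the source may bear on it.

Two compounds sharing one core have numbers in an ADME assay on L02 cells (Homo sapiens) for antiproliferative activity, read by MTT assay, with a stated time of 48 h; on this read-out higher numbers stand for weaker inhibition and lower numbers for stronger inhibition. Compound 1 `CCN(CC)CCNC(=O)c1ccc(C(CC)(CC)c2ccc(OCCC(O)(CC)CC)c(C)c2)n1CC` gives 2290 nM, and compound 2 `CCn1c(C(=O)NCCN)ccc1C(CC)(CC)c1ccc(OCCC(O)(CC)CC)c(C)c1` gives 2940 nM. Compound 2 therefore stands within the scatter of compound 1, and the two cannot be told apart on these numbers.

Compound 3 `CCn1c(C(=O)N(CCC#N)CCC#N)ccc1C(CC)(CC)c1ccc(OCCC(O)(CC)CC)c(C)c1` has yet to be measured in this assay. It differs from compound 2 as follows: a group of 9 heavy atoms (6 carbon, 3 nitrogen; no ring) in place of a group of 4 heavy atoms (2 carbon, 2 nitrogen; no ring), on a carbonyl carbon. The exchange takes place on a carbonyl carbon, and the entering group carries 2 triple bonds outside aromatic rings.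

Within the data shown here, the only measured step is a 1.3-fold higher number from compound 1 to compound 2 (0.11 log units; within the scatter), with amino in place of diethylamino on a saturated chain carbon. It bears on the new change only in part. Among the measured compounds shown here, no measured compound shows the (2-aminoethyl)amino group leaving as a whole, so the direction rests on thin evidence. A modest move towards a higher number is nonetheless expected, with no change beyond the scatter also possible. The estimate amounts to an expected 1.5-fold higher number from compound 2 to compound 3 (0.18 log units; within the scatter). For compound 3 the expected value is 4500 nM, with an estimated range from 1500 nM to 15000 nM.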

Compound 3, half-maximal inhibitory concentration: 37800 nM
For compound 3 the middle estimate is 8.4-fold (0.92 log units) below the measured one; the measured number lies above the stated range.
By their numbers in this assay, from the lowest: compounds 1 and 2 (each within the scatter of the next); then compound 3.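

Among these compounds, compound 3 shows that the group on this carbonyl carbon can move the number far more than the earlier compounds suggested. In this assay the exchange of the whole (2-aminoethyl)amino group for the group of 9 heavy atoms, with its 2 triple bonds outside aromatic rings and 0 hydrogen-bond donors, gives a 13-fold higher number from compound 2 to compound 3 (1.11 log units; beyond the scatter) on the way to weaker inhibition, whereas the change at the chain end alone stayed within the scatter; the same entering group, set against the diethylamino-bearing side chain, gives a 17-fold higher number from compound 1 to compound 3 (1.22 log units; beyond the scatter) in the same direction, so the outcome does not hang on which of the two amine chains it replaces. Nothing offered here explains the shift.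

The exchange changes several things at once, so the compounds shown leave open whether the loss follows from the nitrile ends, from the added chain, or from the absence of the amide hydrogen. As far as these compounds go, a single nitrile-bearing chain that keeps the amide hydrogen, or chains of the same shape ending in an amine, would separate these, and how a carboxylic acid at this place would read remains equally open.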